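A pyrrolidine amide in place of a lactam

The source may report more compounds than this note shows. Statements on the series, on what has been measured and on what is new or still open speak of the compounds shown alone.

Compound 1 `O=C1CCCN1CCCSc1nc2cc(Cl)ccc2o1` was tested in an ADME assay on microsomes from liver (Mus musculus) for metabolic stability, read by LC-MS, using NADPH, with a stated time of 45 min, tested at 0.5 uM (a higher number here means faster removal of the compound, a lower number slower removal), where compound 1 gives 51 mL/min/g. Two related compounds were measured alongside it: compound 2 `O=C(CCSc1nc2c(Cl)cccc2o1)N1CCCC1` gives 97.9 mL/min/g in this assay, and compound 3 `CC1CCN(C(=O)CCSc2nc3cc(Cl)ccc3o2)C1` gives 90.7 mL/min/g. Both numbers sit within the usual scatter of the value for compound 1, so the three cannot be ranked with confidence. Compound 4 `O=C(CCCSc1nc2cc(Cl)ccc2o1)N1CCCC1` has not yet been measured in this assay. It differs from compound 1 by (pyrrolidin-1-yl)carbonyl in place of 2-oxopyrrolidin-1-yl on a saturated chain carbon, three bonds along the chain from a sulfur. Going by the values given here, with no measured pair showing this change, the expectation rests on compounds 2 and 3, which carry the same entering group and give numbers near the upper edge of the scatter. The step from compound 1 to compound 4 is therefore expected to be small and upward, a 1.7-fold higher number from compound 1 to compound 4 (0.22 log units; within the scatter), but probably not beyond the scatter. Compound 4 is estimated to give 85 mL/min/g in this assay, with a likely range from 45 mL/min/g to 160 mL/min/g.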

Compound 4, intrinsic clearance in a liver preparation (reported as CLH), per the amount of preparation that the assay uses: 125 mL/min/g
Estimate against measurement, compound 4: 1.5-fold (0.17 log units) below; low and high end bracket the measured number.
By their numbers in this assay, from the lowest: compounds 1, 3, 2 and 4 (each within the scatter of the next, the first and the last beyond it).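

The change of 2-oxopyrrolidin-1-yl to (pyrrolidin-1-yl)carbonyl at this chain position now has a direct comparison in this assay: a 2.5-fold higher number from compound 1 to compound 4 (0.39 log units; beyond the scatter). The step is modest, yet it shows that removal in this assay responds to the swap, even though the two groups share the same ring size and the same printed count of hydrogen-bond acceptors. No available measurement explains the rise. As far as these compounds go, it remains open whether a piperidine amide or a dimethylamide in the same place would give a number closer to that of compound 1 or compound 4.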